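A few compounds are considered here, and "the series" means these few. Any claim that something is new, unique, unknown or untested is made for them only; others in the source may bear on it.

Compound 1 `CCOc1cc(C(C)(C)C)ccc1C1=NC(c2ccc(Cl)cc2)C(c2ccc(Cl)cc2)N1C(=O)N1CCN(CCCCCC(=O)NO)CC1`: 4030 nM
Compound 2 `CCOc1cc(C(C)(C)C)ccc1C1=NC(c2ccc(Cl)cc2)C(c2ccc(Cl)cc2)N1C(=O)NCCCCCCCC(=O)NO`: 5030 nM
Compound 3 `CCOc1cc(C(C)(C)C)ccc1C1=NC(c2ccc(Cl)cc2)C(c2ccc(Cl)cc2)N1C(=O)N1CCN(Cc2ccc(C(=O)NO)cc2)CC1`: 2030 nM

These values come from a functional assay on HCT-116 cells (Homo sapiens) for antiproliferative activity, read by CCK-8 assay, with a stated time of 72 h; on this read-out lower numbers stand for stronger inhibition and higher numbers for weaker inhibition. The three compounds share one core and differ in the hydroxycarbamoyl-bearing group attached to it. Compound 3 cannot be separated from compound 1 on these numbers, but its gap from compound 2 goes beyond the scatter.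

The unmeasured compound 4 `CCOc1cc(C(C)(C)C)ccc1C1=NC(c2ccc(Cl)cc2)C(c2ccc(Cl)cc2)N1C(=O)N1CCN(c2ncc(C(=O)NO)cn2)CC1` differs from compound 3 in one place: 5-(hydroxycarbamoyl)pyrimidin-2-yl replaces 4-(hydroxycarbamoyl)benzyl on an amine nitrogen in a ring (5-(hydroxycarbamoyl)pyrimidin-2-yl in place of 4-(hydroxycarbamoyl)benzyl on an amine nitrogen in a ring). Among the measured compounds shown here, only one measured step bears on this change, and only loosely: a 2.0-fold lower number from compound 1 to compound 3 (0.30 log units; within the scatter). There, 4-(hydroxycarbamoyl)phenyl took the place of 4-(hydroxycarbamoyl)butyl on a saturated chain carbon bound to an amine nitrogen in a ring. That swap of one group for a quite different one did not move the number beyond the scatter. For the measured compounds named here, no measured compound carries an aromatic ring with hetero atoms in this part of the structure, so the data give no direction for the new step. In this assay, the expectation is therefore no step beyond the scatter, and the estimated step is a 1.2-fold higher number from compound 3 to compound 4 (0.09 log units; within the scatter). The estimated value for compound 4 is 2500 nM, with an expected range from 1000 nM to 6500 nM.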

Compound 4, half-maximal inhibitory concentration: 980 nM
The estimate for compound 4 lay 2.6-fold (0.41 log units) above the measured number; measured number outside the range, below it.
By their numbers in this assay, from the lowest: compound 4; then compounds 3, 1 and 2 (each within the scatter of the next, the first and the last beyond it).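

In this assay, the amine nitrogen of the six-membered ring now proves to be a place where a change can move the number beyond the scatter: 5-(hydroxycarbamoyl)pyrimidin-2-yl in place of 4-(hydroxycarbamoyl)benzyl gives a 2.1-fold lower number from compound 3 to compound 4 (0.32 log units; beyond the scatter) and so goes further than the earlier swap in this part of the structure. Measured against the open chain of 5-(hydroxycarbamoyl)pentyl, the same group gives a 4.1-fold lower number from compound 1 to compound 4 (0.61 log units; beyond the scatter) and shows that an aromatic ring with 2 hetero atoms can serve here as the carrier of the hydroxycarbamoyl group. No evidence is at hand on what lies behind the lower numbers.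

The step to compound 4 changes two things at once, the ring itself and the loss of the benzyl carbon, so its effect cannot be assigned to either one alone. A 4-(hydroxycarbamoyl)phenyl group or a hydroxycarbamoyl-bearing pyridine ring set directly on the same nitrogen would be needed to pull those two changes apart.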